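Swapping Thiophene for Furan in a Seven-Membered Ring Series

The source may report more compounds than this note shows. Statements on the series, on what has been measured and on what is new or still open speak of the compounds shown alone.

Compound 1, with structure `Cc1ccc([C@@H]2C[C@H](O)Cc3ccccc3N2)s1`, and compound 2, with structure `Cc1ccc([C@@H]2C[C@H](O)Cc3cc(F)ccc3N2)s1`, were both tested in an ADME assay on Vero cells (Chlorocebus sabaeus) for cytotoxicity; on this read-out higher numbers stand for lower toxicity in this test and lower numbers for higher toxicity in this test. Compound 1 gives 956000 nM, and compound 2 gives 801000 nM. Compound 1 holds the higher of these two numbers, but the step of a 1.2-fold lower number from compound 1 to compound 2 (0.08 log units; within the scatter) means the two compounds cannot be told apart on this read-out. Compound 3, with structure `Cc1ccc([C@@H]2C[C@H](O)Cc3ccccc3N2)o1`, has not yet been measured in this assay. It differs from compound 1 by 5-methylfuran-2-yl in place of 5-methylthiophen-2-yl on a saturated ring carbon. Within the data shown here, no measured pair among the compounds so far shows this kind of exchange; the only step measured so far, fluoro in place of hydrogen on an aromatic carbon, stays within the scatter. Without a matching precedent, the expectation for compound 3 in this assay is no movement beyond the scatter, so the estimated step of a 1.1-fold lower number from compound 1 to compound 3 (0.03 log units; within the scatter) is expected to be small. Compound 3 is therefore estimated at 900000 nM, with a range from 400000 nM to 2000000 nM.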

Compound 3, half-maximal cytotoxic concentration: 370000 nM
For compound 3 the middle estimate is 2.4-fold (0.39 log units) above the measured one; the whole stated range lies above it.
By their numbers in this assay, from the lowest: compound 3; then compounds 2 and 1 (each within the scatter of the next).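

In this assay, among these compounds, 5-methylfuran-2-yl in place of 5-methylthiophen-2-yl gives a 2.6-fold lower number from compound 1 to compound 3 (0.41 log units; beyond the scatter), the first step in this small set to lie beyond the scatter. The fluoro exchange on an aromatic carbon, a 1.2-fold lower number from compound 1 to compound 2 (0.08 log units; within the scatter), did not show that the read-out could move at all, whereas this change, on a saturated ring carbon next to the ring nitrogen, shows that it can, with the lower number pointing to higher toxicity in this test. The two groups have the same counts of heavy atoms, hydrogen-bond donors and acceptors and neither carries a net charge, so the step comes with sulfur leaving the five-membered aromatic ring and oxygen entering it, although nothing available here explains how that exchange produces the step.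

On these data alone, it remains open whether the same exchange would give a similar step on the fluoro-bearing core of compound 2. As far as these compounds go, it is also open whether a phenyl ring, or a thiophene without its methyl group, at this place would give a number close to that of compound 1 or close to that of compound 3.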